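Catechol ether benzamides: from an aryl amide to a thiazolyl amide

The source may report more compounds than this note shows. Statements on the series, on what has been measured and on what is new or still open speak of the compounds shown alone.

The measured compounds and their values:
compound 1, `COc1ccc(C(=O)Nc2ccccc2C)cc1OC1CCCC1`, 300 nM
compound 2, `CCCCOc1cc(C(=O)Nc2c(F)cccc2F)ccc1OC`, 300 nM
compound 3, `COc1ccc(C(=O)Nc2c(Cl)cccc2Cl)cc1OC1CC2CCC1C2`, 10 nM

All three were tested in an assay on isolated protein for inhibition of phosphodiesterase 4A (Sus scrofa); on this read-out lower numbers stand for stronger inhibition and higher numbers for weaker inhibition. Compound 1 stands level with compound 2 at the digits shown; the two together hold the highest numbers of the three, and the gap between them lies within the scatter. The furthest from compound 1 is compound 3, whose number is lower by a margin that lies well beyond the scatter, so compound 3 is the strongest inhibitor of the three on this read-out.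

The unmeasured compound 4, `COc1ccc(C(=O)Nc2nccs2)cc1OC1CCCC1`, differs from compound 1 in one place: 1,3-thiazol-2-yl in place of 2-methylphenyl on an amide-type nitrogen. For the measured compounds named here, no pair of measured compounds traces this change, so its effect on this assay is unknown. The one measured contrast at the amide nitrogen, between compound 1 and compound 3, involves other substituents as well and cannot be read as a guide. A step of modest size, in either direction, with the number for compound 4 most likely staying near that of compound 1, is expected; the estimated step of a 1.3-fold higher number from compound 1 to compound 4 (0.12 log units; within the scatter) reflects this. Compound 4 is expected to give about 400 nM in this assay, within a range from 80 nM to 2000 nM.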

Compound 4, half-maximal inhibitory concentration: 6500 nM
The estimate for compound 4 lay 16-fold (1.21 log units) below the measured number, and the stated range ends below it.
By their numbers in this assay, from the lowest: compound 3; then compounds 1 and 2 (each within the scatter of the next); then compound 4.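

The result shows that the group on the amide-type nitrogen cannot be exchanged freely for another aromatic ring: in this assay, placing 1,3-thiazol-2-yl where 2-methylphenyl stood gives a 22-fold higher number from compound 1 to compound 4 (1.34 log units; beyond the scatter), a large step beyond the scatter. The earlier compounds shown here could not show this, since no two of them differ in one place and none carries a five-membered aromatic ring with hetero atoms on that nitrogen. No measurement at hand bears on what lies behind the step.

The change alters several things at once, replacing a six-membered ring of carbon only with a five-membered ring holding nitrogen and sulfur and removing the methyl group, so the compounds shown leave open which of these differences matters. On these data alone, how a plain phenyl, a pyridin-2-yl or a 1,3-oxazol-2-yl group would stand on this nitrogen remains open, as does whether 1,3-thiazol-2-yl would give a step of similar size on the core of compound 2 or compound 3.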